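The compounds below may be only part of what the source reports. "The series", "measured", "known", "first", "only" and "open" are said of these compounds alone.

Measured so far in a functional assay on HCT-116 cells (Homo sapiens) for cytotoxicity, read by MTT assay, with a stated time of 72 h; a lower number here means a stronger inhibitor, a higher number a weaker inhibitor:

- Compound 1 `N[C@H]1CC[C@H](Nc2c(C(=O)NCc3ccc(F)cc3)nc(N3CCCCS3(=O)=O)c3cccnc23)CC1`: > 10000 nM
- Compound 2 `CS(=O)(=O)Oc1c(C(=O)NCc2ccc(F)cc2)nc(Br)c2cccnc12`: > 20000 nM
- Compound 3 `C[C@@H](Nc1c(C(=O)NCc2ccc(F)cc2)nc(Br)c2cccnc12)c1ccccc1`: > 20000 nM

Each of these entries is a limit of the assay and not a number. On these data alone, compound 3 sits at > 20000 nM, which is a limit, so its true position on the scale is unknown. Among the measured compounds shown here, it shares this position with compound 2, and no measured compound yet offers a number to compare against.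

The next compound is compound 4 `Nc1ccc(Nc2c(C(=O)NCc3ccc(F)cc3)nc(Br)c3cccnc23)cc1`, which has not yet been measured. It carries 4-aminophenyl in place of 1-phenylethyl on a nitrogen on an aromatic ring.

For the measured compounds named here, only one measured step bears on this change, and it involves the same nitrogen-linked group of compound 3: a step that the two limits leave unreadable from compound 2 to compound 3. That step gives no size to carry forward. The other evidence is only (the limit of > 10000 nM in this assay, at which 1 of the 3 values shown sits), together with the limit of > 20000 nM in this assay, at which 2 of the 3 values shown sit. Going by the values given here, the data therefore support no firm step in this assay. The likeliest outcome is that compound 4 also stays weak and may again be reported only as a limit, with a modest chance of a measurable value on the stronger side.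

The expected change is an at least 1.3-fold lower number from compound 3 to compound 4 (0.12 log units; that floor lies within the scatter). For compound 4 the estimated value is 15000 nM, with an expected range from 5000 nM to 30000 nM.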

Compound 4, half-maximal inhibitory concentration: 7000 nM
Compound 4: middle estimate off by 2.1-fold (0.33 log units), on the high side; measured number inside the range.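

In this assay, among the compounds shown here, compound 4 gives the first true number in this set, 7000 nM, so a group on this nitrogen can bring the series into measurable range. Putting 4-aminophenyl in place of 1-phenylethyl is an at least 2.8-fold lower number from compound 3 to compound 4 (0.45 log units; beyond the scatter), and putting (4-aminophenyl)amino in place of (methylsulfonyl)oxy on the aromatic carbon is an at least 2.8-fold lower number from compound 2 to compound 4 (0.45 log units; beyond the scatter); each size is only a floor, and the true gap may be larger. The step from compound 2 to compound 3 cannot be read, and both compounds remain at a limit of the assay: the limit of > 20000 nM in this assay, at which 2 of the 4 values shown sit.

The change from compound 3 to compound 4 removes a defined stereocentre and adds a hydrogen-bond donor and acceptor all at once, and the data do not show which of these matters, a question that a plain phenyl or a 4-hydroxyphenyl on the same nitrogen could help to settle. Compound 1 differs from compound 4 in more than one place, so it cannot show whether the 4-aminophenyl group would keep this gain with a different group in place of the bromine.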